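Anilino on the Pyridine Ring of a Vanilloid Receptor Antagonist

The source may hold more compounds than are shown below. What is called first, only, known or untested is meant among the compounds shown, and "the series" means these compounds.

Measured compounds:
compound 1 `CC(C(=O)NCc1ccc(C(F)(F)F)nc1)c1ccc(NS(C)(=O)=O)c(F)c1` — "not active" (no number reported)
compound 2 `CCCCNc1nc(C(F)(F)F)ccc1CNC(=O)C(C)c1ccc(NS(C)(=O)=O)c(F)c1` — 293 nM
compound 3 `CC1CCC(Nc2nc(C(F)(F)F)ccc2CNC(=O)C(C)c2ccc(NS(C)(=O)=O)c(F)c2)CC1` — 1130 nM

In a functional assay on CHO-K1 cells for antagonist activity at transient receptor potential cation channel subfamily V member 1 (Homo sapiens), read by FLIPR (on this read-out higher numbers stand for weaker inhibition and lower numbers for stronger inhibition), compound 1 is reported as "not active" (no number reported), so no single number marks where it stands. Compounds 2 and 3 carry a substituent on the nitrogen next to the ring nitrogen of the shared core, and both give numbers in this assay: compound 2 gives 293 nM, compound 3 gives 1130 nM. Among the compounds with values here, the one step that compares two such substituents is a 3.9-fold higher number from compound 2 to compound 3 (0.59 log units; beyond the scatter). Compound 4 `CC(C(=O)NCc1ccc(C(F)(F)F)nc1Nc1ccccc1)c1ccc(NS(C)(=O)=O)c(F)c1` differs from compound 1 by anilino in place of hydrogen on an aromatic carbon. As compounds 2 and 3 show, a group at that carbon goes with measurable inhibition in this assay where compound 1 shows none, so compound 4 is expected to register a number, roughly in their region. Compound 4 is therefore estimated at 600 nM, within 120 nM to 3000 nM.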

Compound 4, half-maximal inhibitory concentration: 1400 nM
Beside the measured number, compound 4's estimate is 2.3-fold (0.37 log units) below it; measured number inside the range.
By their numbers in this assay, from the lowest: compound 2; then compounds 3 and 4 (each within the scatter of the next).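

With anilino in place of hydrogen on this aromatic carbon, compound 4 gives a number in this assay, where compound 1 gives "not active" (no number reported). On that nitrogen, phenyl and 4-methylcyclohexyl cannot be told apart, with a 1.2-fold higher number from compound 3 to compound 4 (0.09 log units; within the scatter), whereas phenyl and butyl can, with a 4.8-fold higher number from compound 2 to compound 4 (0.68 log units; beyond the scatter). Nothing shown here accounts for these numbers.

Open, from the compounds shown here alone, is how a methoxy group or a chlorine on the phenyl ring would read. So is how a shorter chain such as ethyl, or a benzyl group on that nitrogen, would compare with compound 2.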